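The compounds below may be only part of what the source reports. "The series", "measured", "known", "first", "only" and "open" are said of these compounds alone.

Among the compounds with values here, compound 1 (`Cc1c(C(=O)N/N=C/c2ccc(N(C)C)cc2)no[n+]1[O-]`) gives 129000 nM in an ADME assay on J744 cells (Mus musculus) for cytotoxicity, read by MTT assay, with a stated time of 48 h (on this read-out higher numbers stand for weaker inhibition and lower numbers for stronger inhibition), and compound 2 (`Cc1c(C(=O)N/N=C/c2ccc([N+](=O)[O-])o2)no[n+]1[O-]`) gives 96000 nM there, two numbers that lie within the scatter of each other at the high end of the three so far. Within the data shown here, compound 3 (`O=C(N/N=C/c1ccc2no[n+]([O-])c2c1)c1cccnc1`) gives 31000 nM and is the one compound lower than compound 1 by more than the scatter. Compound 4 (`Cc1c(C(=O)N/N=C/c2ccc(C(F)(F)F)cc2)no[n+]1[O-]`) is still unmeasured. It carries trifluoromethyl in place of dimethylamino on an aromatic carbon of a six-membered aromatic ring of carbon only, para to a large group. Among the measured compounds shown here, no measured pair differs in one place, so the data hold no direct guide to this exchange. With a different substituted ring from compound 1, compound 2 gives 96000 nM and stays within the scatter, and on that slim basis no step beyond the scatter is expected in this assay in either direction. The estimate is a small drop, an expected 1.3-fold lower number from compound 1 to compound 4 (0.11 log units; within the scatter) that stays inside the scatter. For compound 4 the estimated value is 100000 nM with an expected range from 45000 nM to 220000 nM in this measurement.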

Compound 4, half-maximal inhibitory concentration: > 400000 nM
Compound 4: only a limit was reported; the forecaster's own chance of this, stated with the estimate: 15%; at least 4.0-fold (0.60 log units) between middle value and limit.
By their numbers in this assay, from the lowest: compound 3; then compounds 2 and 1 (each within the scatter of the next). At a limit, above all of these: compound 4.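

In this assay compound 4 gives > 400000 nM, which is a limit of the assay and not a number. Within the data shown here, this is the first direct reading of a change at this position, on a six-membered aromatic ring of carbon only, para to a large group: trifluoromethyl in place of dimethylamino on an aromatic carbon brings an at least 3.1-fold higher number from compound 1 to compound 4 (0.49 log units; beyond the scatter), so the group here can move this read-out beyond the scatter, towards weaker inhibition. The full size of the step stays unknown, since it rests on a limit: the limit of > 400000 nM in this assay, at which 1 of the 4 values shown sits.

The compounds shown give only this one exchange at this position, so they do not separate the loss of dimethylamino from the gain of trifluoromethyl. Where a methoxy group or a carboxylic acid in the same place would fall on this read-out remains open.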